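From pyridin-2-yl to pyridin-4-yl in compound 4

A few compounds are considered here, and "the series" means these few. Any claim that something is new, unique, unknown or untested is made for them only; others in the source may bear on it.

Within the data shown here, in a functional assay on MCF7 cells (Homo sapiens) for antiproliferative activity, read by MTT assay, with a stated time of 48 h (on this read-out higher numbers stand for weaker inhibition and lower numbers for stronger inhibition), compound 3 `CC(=O)N1N=C(c2ccc3ccccc3c2)OC1c1ccccn1` gives 6.02 ug/mL as the highest number of the three measured so far, and its steps to both others lie beyond the scatter. Compound 1 `CC(=O)N1N=C(c2ccc3ccccc3c2)OC1c1cccc(Br)c1` gives 2.34 ug/mL and compound 2 `CC(=O)N1N=C(c2ccc3ccccc3c2)OC1c1ccc(Cl)cc1` gives 2.63 ug/mL and, with a 1.1-fold higher number from compound 1 to compound 2 (0.05 log units; within the scatter) between them, these two cannot be told apart. Both a 2.6-fold higher number from compound 1 to compound 3 (0.41 log units; beyond the scatter) and a 2.3-fold higher number from compound 2 to compound 3 (0.36 log units; beyond the scatter) are modest moves toward weaker inhibition, seen when pyridin-2-yl replaces a substituted phenyl. Compound 4 `CC(=O)N1N=C(c2ccc3ccccc3c2)OC1c1ccncc1` keeps the shared core and carries pyridin-4-yl in place of pyridin-2-yl on a saturated ring carbon so the two have the same atoms, joined differently. Among the measured compounds shown here, no measured step compares one pyridine with another, so the data give no direction, and the most reasonable expectation is no step beyond the scatter. The estimated change is a 1.2-fold lower number from compound 3 to compound 4 (0.06 log units; within the scatter) and stays within the scatter. For compound 4 the expected value is 5.2 ug/mL with an estimated range from 2.6 ug/mL to 10 ug/mL as the likely span.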

Compound 4, half-maximal inhibitory concentration: 2.56 ug/mL
Compound 4: middle estimate off by 2.0-fold (0.31 log units), on the high side, outside the stated range (below it).
By their numbers in this assay, from the lowest: compounds 1, 4 and 2 (each within the scatter of the next); then compound 3.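

In this assay, moving the ring nitrogen from pyridin-2-yl to pyridin-4-yl gives a 2.4-fold lower number from compound 3 to compound 4 (0.37 log units; beyond the scatter), so at this saturated ring carbon the way the same atoms are joined matters, and a pyridine ring as such does not go with the higher number. Compound 4 cannot be told apart from the two halogen-bearing phenyl compounds, as both a 1.0-fold lower number from compound 2 to compound 4 (0.01 log units; within the scatter) and a 1.1-fold higher number from compound 1 to compound 4 (0.04 log units; within the scatter) show, which leaves pyridin-2-yl as the only group shown here with a higher number. Nothing measured here explains the difference between the two pyridines.

Still open, as far as these compounds go, is where pyridin-3-yl would fall relative to these two pyridines. Also unknown is how a phenyl ring carrying an amine or a carboxylic acid would behave at this position.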